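The source may hold more compounds than are shown below. What is called first, only, known or untested is meant among the compounds shown, and "the series" means these compounds.

Three compounds share one core, differing only in the group attached through the sulfonamide. Compound 1 `COc1ccc(NS(=O)(=O)c2ccc3c(Cl)cccc3c2)cc1N1CCN(C)CC1` gives 0.794 nM in an assay on HeLa cells for binding affinity to 5-hydroxytryptamine receptor 6 (Homo sapiens) (on this read-out lower numbers stand for stronger inhibition and higher numbers for weaker inhibition), and compound 3 `COc1ccc(NS(=O)(=O)c2c(C)sc3ccc(Cl)cc23)cc1N1CCN(C)CC1` gives 1.26 nM. Compound 2 `COc1ccc(NS(=O)(=O)c2cccc([N+](=O)[O-])c2)cc1N1CCN(C)CC1` gives 79.4 nM, the highest of the three numbers and beyond the scatter from both others, so on this read-out compound 2 is the weakest binder shown.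

Compound 4 `COc1ccc(NS(=O)(=O)c2cccc(I)c2)cc1N1CCN(C)CC1` is not yet measured. It differs from compound 2 in one place: iodo in place of nitro on an aromatic carbon. For the measured compounds named here, no measured pair shows this change, so the expectation rests on compound 2 alone. The step from compound 2 to compound 4 is estimated at a 4.0-fold lower number from compound 2 to compound 4 (0.60 log units; beyond the scatter), a move toward a lower number that is expected to exceed the scatter. Compound 4 is estimated to give 20 nM, within 5 nM to 100 nM.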

Compound 4, inhibition constant: 0.794 nM
Beside the measured number, compound 4's estimate is 25-fold (1.40 log units) above it, outside the stated range (below it).
By their numbers in this assay, from the lowest: compounds 1, 4 and 3 (each within the scatter of the next); then compound 2.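

Iodo in place of nitro on this aromatic carbon, meta to a large group, gives a 100-fold lower number from compound 2 to compound 4 (2.00 log units; beyond the scatter) in this assay. For the compounds shown here, this is the first pair differing in one place, and it shows that this single group can shift the number by a large amount. Nothing measured here explains why the step is so large. Whether other groups on this carbon would match iodo stays open, since bromo, an amine and a carboxylic acid do not appear among the compounds shown.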